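A Single Group Change at the Low End

This account rests on a few compounds, and the source may have more. Where it says the series, first, only, none or still open, it means among the compounds named here.

Measured in an ADME assay on HEK-293T cells (Homo sapiens) for cytotoxicity, read by MTT assay, with a stated time of 24 h; on this read-out lower numbers stand for higher toxicity in this test and higher numbers for lower toxicity in this test:
Compound 1 `Cc1ccc(-c2nn(-c3ccccc3)cc2-c2nc3ccccc3n2S(=O)(=O)c2ccccc2)cc1` gives 138000 nM
Compound 2 `Cc1ccc(-c2nn(-c3ccccc3)cc2-c2nc3ccccc3n2S(=O)(=O)c2ccc(Br)cc2)cc1` gives 159000 nM
Compound 3 `COc1ccc(S(=O)(=O)n2c(-c3cn(-c4ccccc4)nc3-c3ccc(F)cc3)nc3ccccc32)cc1` gives 37300 nM

Of these three numbers, compound 3 has the lowest, and its gaps to compound 1 and compound 2 both lie beyond the usual scatter. The next molecule, compound 4 `O=S(=O)(c1ccc(Cl)cc1)n1c(-c2cn(-c3ccccc3)nc2-c2ccc(F)cc2)nc2ccccc21`, changes one group of compound 3: chloro in place of methoxy on an aromatic carbon, para to a large group (chloro in place of methoxy on an aromatic carbon). Within the data shown here, only one measured step offers guidance on a change of this kind. That step is a 1.2-fold higher number from compound 1 to compound 2 (0.06 log units; within the scatter), with bromo in place of hydrogen on an aromatic carbon, and it stays within the scatter. Among the measured compounds shown here, it is a different swap, however, and no measured step shows what happens when methoxy leaves, so the guidance is weak. The small size of that step argues against a large shift. Compound 3 also sits at the low end of a small set, so a modest upward move is the cautious guess. Expected is a 1.6-fold higher number from compound 3 to compound 4 (0.21 log units; within the scatter), a step that may well stay within the scatter. For compound 4 the estimated value is 60000 nM, with an expected range from 25000 nM to 150000 nM.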

Compound 4, half-maximal cytotoxic concentration: 93100 nM
Estimate against measurement, compound 4: 1.6-fold (0.19 log units) below; the range from low to high includes it.
By their numbers in this assay, from the lowest: compound 3; then compounds 4, 1 and 2 (each within the scatter of the next).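

Among these compounds, replacing methoxy with chloro on the ring of the sulfonyl group gives a 2.5-fold higher number from compound 3 to compound 4 (0.40 log units; beyond the scatter) in this assay, a modest change, but the first single-group step in this set to lie beyond the scatter. Among the compounds shown here, the only earlier step, a 1.2-fold higher number from compound 1 to compound 2 (0.06 log units; within the scatter), placed bromo where hydrogen had been on the matching ring of a different pair and stayed within the scatter, so it gave no sign that a change on this ring could move the number measurably. The step from 4-methoxyphenyl to 4-chlorophenyl now shows that it can, although no supporting measurement here accounts for the shift.

The compounds shown cannot separate the effect of losing methoxy from that of gaining chloro, and the core of compound 3 with a plain hydrogen on this ring would be the most direct link between them. As far as these compounds go, it also remains open how an amine or a carboxylic acid would read at this place, para to a large group, and whether the same swap from methoxy to chloro would give a similar step on the core of compound 1.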